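This account rests on a few compounds, and the source may have more. Where it says the series, first, only, none or still open, it means among the compounds named here.

Series notes. Compound 1 is `CCOC(=O)c1cn(Cc2ccccc2)c2c(C#N)c(-c3ccc(OC)cc3)c(CN(C)C)n2c1=O`. In an assay on HEK293 cells for binding affinity to Gonadotropin-releasing hormone receptor (Homo sapiens), read by radioligand binding (a lower number here means a stronger inhibitor, a higher number a weaker inhibitor), compound 1 gives > 50000 nM, which is a limit of the assay and not a number. Compound 2 is `CCOC(=O)c1cn(Cc2ccccc2)c2c(C#N)c(-c3ccc(OC)cc3)c(CN(C)Cc3ccccc3)n2c1=O`, and in this assay compound 2 gives 42000 nM. Among the measured compounds shown here, the one measured step, an at least 1.1-fold lower number from compound 1 to compound 2 (0.07 log units; that floor lies within the scatter), has its floor set by the limit of > 50000 nM in this assay, at which 1 of the 2 values shown sits. For the measured compounds named here, compound 2 therefore stands as the only number so far in this assay; the one other value is a limit.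

Compound 3 is `CCOC(=O)c1cn(Cc2ccccc2F)c2c(C#N)c(-c3ccc(OC)cc3)c(CN(C)Cc3ccccc3)n2c1=O`. It differs from compound 2 by fluoro in place of hydrogen on an aromatic carbon. Going by the values given here, no measured step changes a six-membered aromatic ring of carbon only; the single step, an at least 1.1-fold lower number from compound 1 to compound 2 (0.07 log units; that floor lies within the scatter), concerns a saturated chain carbon bound to an amine nitrogen, and its size is not resolved beyond the scatter. The measured data thus give no direction for this assay on this change. The expected step is a 1.1-fold lower number from compound 2 to compound 3 (0.02 log units; within the scatter). Compound 3 is estimated at 40000 nM, with a range from 15000 nM to 100000 nM, and a fair chance that only a limit is reported.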

Compound 3, inhibition constant: 1800 nM
For compound 3 the middle estimate is 22-fold (1.35 log units) above the measured one; measured number outside the range, below it.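

In this assay, among the compounds shown here, replacing one hydrogen with fluoro, which turns a benzyl group into 2-fluorobenzyl, gives a 23-fold lower number from compound 2 to compound 3 (1.37 log units; beyond the scatter), and this is the first step resolved beyond the scatter. For the compounds shown here, the earlier compounds left this aromatic position unexplored, and their only step, an at least 1.1-fold lower number from compound 1 to compound 2 (0.07 log units; that floor lies within the scatter), changes a saturated chain carbon bound to an amine nitrogen; compound 3 now shows that a change of one heavy atom on this aromatic ring can move the number far more than that floor shows. No measurement shown accounts for the size of this step.

As far as these compounds go, it remains open whether the step belongs to fluoro specifically or would also appear with chloro, methyl or methoxy at this place on the ring. From the compounds shown here alone, it is equally open whether the step would carry over when a piperidine or morpholine replaces the amine of compound 3, or when a carboxylic acid replaces the ethyl ester.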